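The source may hold more compounds than are shown below. What is called first, only, known or untested is meant among the compounds shown, and "the series" means these compounds.

Of the compounds shown here, two have a solubility number so far. Compound 1 `O=[N+]([O-])c1cn2c(n1)OC[C@@H](NCc1ccc(OC(F)(F)F)c(F)c1)C2` and compound 2 `O=[N+]([O-])c1cn2c(n1)OC[C@@H](NCc1ccc(OC(F)(F)F)cc1F)C2` share one core and differ only in where the fluoro sits on the benzyl ring. In a physicochemical assay for solubility, at pH 6.8 (on this read-out lower numbers stand for lower solubility and higher numbers for higher solubility), compound 1 gives 43 ug/mL, and in this assay compound 2 gives 72 ug/mL. Compound 2 holds the higher of the two numbers, but the gap to compound 1 lies within the scatter, so the two read as alike.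

Compound 3 `O=[N+]([O-])c1cn2c(n1)OC[C@@H](NCc1ccc(OC(F)(F)F)cc1OCC1CC1)C2` is not yet measured. It differs from compound 2 in one place: cyclopropylmethoxy in place of fluoro on an aromatic carbon. Among the compounds with values here, no step between measured compounds exists to guide this change, so the expectation rests on the size of the group that enters alone. A step downward, beyond the scatter, is expected for compound 3, namely a 4.8-fold lower number from compound 2 to compound 3 (0.68 log units; beyond the scatter). Compound 3 is thus estimated at 15 ug/mL, with a range from 4 ug/mL to 50 ug/mL.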

Compound 3, solubility: 6 ug/mL
Compound 3: middle estimate off by 2.5-fold (0.40 log units), on the high side; low and high end bracket the measured number.
By their numbers in this assay, from the lowest: compound 3; then compounds 1 and 2 (each within the scatter of the next).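

In this assay, within the data shown here, cyclopropylmethoxy in place of fluoro on this aromatic carbon, ortho to a large group and meta to a trifluoromethoxy group, gives a 12-fold lower number from compound 2 to compound 3 (1.08 log units; beyond the scatter), the first step that clears the scatter. Compounds 1 and 2, which differ only in where the fluoro sits, read as alike, whereas this exchange shows that the read-out can respond strongly to what this carbon carries. No measurement at hand bears on what lies behind the step.

This single exchange brings in the ether oxygen, the three-membered ring and the added heavy atoms together, so their shares cannot be separated. On these data alone, whether a methoxy group on this carbon reads closer to compound 2 or to compound 3, and where an amine or a carboxylic acid there would fall, stays open.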